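Working notes: from compound 2 to compound 4

The source may hold more compounds than are shown below. What is called first, only, known or untested is meant among the compounds shown, and "the series" means these compounds.

Measured so far in an ADME assay on MT2 cells (Homo sapiens) for cytotoxicity, read by XTT assay, with a stated time of 4 days (a higher number here means that more compound is tolerated, a lower number that less compound is tolerated), and each value a limit:
- compound 1 (`Cc1nc(C(NC(=O)C(=O)Nc2ccc(Cl)cc2)C2CCNCC2)sc1CO`) gives > 81000 nM as a limit
- compound 2 (`Cc1ccc(NC(=O)C(=O)NC(c2nc(C)c(CCO)s2)C2CCCCN2)c(F)c1`) gives > 78800 nM as a limit
- compound 3 (`Cc1ccc(NC(=O)C(=O)NC(c2nc(C)c(CO)s2)C2CCCCN2)c(F)c1`) gives > 109000 nM as a limit

Compound 2 has no numerical value, only the limit of > 78800 nM in this assay, at which 1 of the 3 values shown sits, and no more than that. The other two values are limits as well, so its rank within the series cannot be read.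

Compound 4 (`Cc1nc(C(NC(=O)C(=O)NC2CCCCCC2)C2CCCCN2)sc1CCO`) departs from compound 2 as follows: cycloheptyl in place of 2-fluoro-4-methylphenyl on an amide-type nitrogen in short, cycloheptyl in place of 2-fluoro-4-methylphenyl on an amide-type nitrogen.

For the measured compounds named here, the one measured step is a step that the two limits leave unreadable from compound 2 to compound 3 and it supplies no size to carry over. Going by the values given here, no measured compound carries cycloheptyl. In this assay no step beyond the scatter is therefore expected, in either direction. The expected change is an at least 1.0-fold lower number from compound 2 to compound 4 (0.02 log units; that floor lies within the scatter) and this estimate is weakly supported. Compound 4 is estimated at 75000 nM with an expected range from 30000 nM to 130000 nM and may well turn out to be only a limit.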

Compound 4, half-maximal cytotoxic concentration: 60000 nM
Compound 4: the middle estimate sits 1.3-fold (0.10 log units) above what was measured; low and high end bracket the measured number.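

In this assay, for the compounds shown here, compound 4 gives 60000 nM, the only value shown that is a number and not a limit. Compound 2 is held only as a limit: the limit of > 78800 nM in this assay, at which 1 of the 4 values shown sits. Cycloheptyl in place of 2-fluoro-4-methylphenyl on an amide-type nitrogen gives an at least 1.3-fold lower number from compound 2 to compound 4 (0.11 log units; that floor lies within the scatter), so this position, until now seen only with aromatic rings, now shows a measurable half-maximal cytotoxic concentration with a seven-membered non-aromatic ring of carbon only, though the step is a floor and its full size stays unread.

From the compounds shown here alone, it remains open whether the number at this position follows ring size or the loss of the aromatic ring, which a cyclohexyl or an unsubstituted phenyl on the same nitrogen would help separate. An amine on the cycloheptyl ring, or a straight hexyl chain in its place, is equally untested in the compounds shown here.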